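The source may hold more compounds than are shown below. What is called first, only, known or untested is meant among the compounds shown, and "the series" means these compounds.

Measured in an ADME assay on Vero cells (Chlorocebus sabaeus) for cytotoxicity; on this read-out higher numbers stand for lower toxicity in this test and lower numbers for higher toxicity in this test:
- compound 1 `O=C1C(=O)N(Cc2cn(CC(=O)N3CCN(c4cc5c(cc4F)c(=O)c(C(=O)O)cn5C4CC4)CC3)nn2)c2c(F)cccc21`: 8 ug/mL
- compound 2 `O=C1C(=O)N(Cc2cn(CC(=O)N3CCN(c4cc5c(cc4F)c(=O)c(C(=O)O)cn5C4CC4)CC3)nn2)c2ccc(F)cc21`: 32 ug/mL
- compound 3 `O=C1C(=O)N(Cc2cn(CC(=O)N3CCN(c4cc5c(cc4F)c(=O)c(C(=O)O)cn5C4CC4)CC3)nn2)c2ccccc21`: 16 ug/mL

Compound 3 is second highest of these three numbers, but it lies within the scatter of both other compounds. Compound 4 `Cc1ccc2c(c1)C(=O)C(=O)N2Cc1cn(CC(=O)N2CCN(c3cc4c(cc3F)c(=O)c(C(=O)O)cn4C3CC3)CC2)nn1` has methyl in place of hydrogen on an aromatic carbon.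

No methyl change has been measured in this series. The closest evidence is the swap of fluoro for hydrogen on an aromatic carbon, seen in a 2.0-fold higher number from compound 1 to compound 3 (0.30 log units; within the scatter) and a 2.0-fold lower number from compound 2 to compound 3 (0.30 log units; within the scatter). Both steps are within the scatter, while the largest step in the set, a 4.0-fold higher number from compound 1 to compound 2 (0.60 log units; beyond the scatter), is modest. No step beyond the scatter is therefore expected in this assay, and the estimate is no change at the digits printed from compound 3 to compound 4 (within the scatter). Compound 4 is expected at 16 ug/mL, within an estimated range of 8 ug/mL to 32 ug/mL.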

Compound 4, half-maximal cytotoxic concentration: 16 ug/mL
Beside the measured number, compound 4's estimate shows no gap at the digits printed; measured number inside the range.
By their numbers in this assay, from the lowest: compounds 1, 3, 4 and 2 (each within the scatter of the next, the first and the last beyond it).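

In this assay, within the data shown here, the first carbon group on this aromatic carbon gives no change at the digits printed from compound 3 to compound 4 (within the scatter) and so cannot be told apart from hydrogen here. Methyl in place of fluoro gives a 2.0-fold lower number from compound 2 to compound 4 (0.30 log units; within the scatter) and the other fluoro comparison gives a 2.0-fold higher number from compound 1 to compound 4 (0.30 log units; within the scatter) so methyl also cannot be told apart from either fluoro compound. Nothing available explains this result.

As far as these compounds go, whether an amine, a methoxy group or a carboxylic acid on this aromatic carbon would move the number beyond the scatter stays open.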